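Working notes on the spiro series, antiproliferative read-out

The compounds below may be only part of what the source reports. "The series", "measured", "known", "first", "only" and "open" are said of these compounds alone.

Measured so far:
Compound 1 `Cc1ccc(Cl)cc1-n1nncc1CN1C(=O)C2(C(C#N)=C(N)Oc3c2c2nc4ccccc4nc2c2ccccc32)c2ccccc21` in an ADME assay on HUVEC cells (Homo sapiens) for antiproliferative activity, read by MTT assay, with a stated time of 48 h (on this read-out lower numbers stand for stronger inhibition and higher numbers for weaker inhibition), gives > 50000 nM, a limit of the assay.
Compound 2 `N#CC1=C(N)Oc2c(c3nc4ccccc4nc3c3ccccc23)C12C(=O)N(Cc1cnnn1-c1cc(Cl)ccc1Cl)c1ccccc12` in this assay gives > 50000 nM, also a limit.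
Compound 3 `CCc1ccccc1-n1nncc1CN1C(=O)C2(C(C#N)=C(N)Oc3c(N)cc4nc5ccccc5nc4c32)c2ccccc21` in this assay gives > 50000 nM, likewise a limit.

Compound 3 thus stands at the limit with no number of its own, as do the other two; all three sit at the limit of > 50000 nM in this assay, at which 3 of the 3 values shown sit. Among the compounds with values here, the single one-place step, chloro in place of methyl on an aromatic carbon, is a step that the two limits leave unreadable from compound 1 to compound 2 and has no readable size. Compound 4 `N#CC1=C(N)Oc2c(N)cc3nc4ccccc4nc3c2C12C(=O)N(Cc1cnnn1-c1ccc([N+](=O)[O-])cc1)c1ccccc12` carries 4-nitrophenyl in place of 2-ethylphenyl on an aromatic nitrogen. Within the data shown here, no measured step covers this change, and none of the three compounds shows a number beneath the limit. The step from compound 3 to compound 4 is therefore expected to be a step that the limit leaves unreadable from compound 3 to compound 4, nothing readable. Compound 4 is expected at 60000 nM, within 20000 nM to 200000 nM, and most likely reported again only as a limit.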

Compound 4, half-maximal inhibitory concentration: > 50000 nM
Compound 4: only a limit was reported; the forecaster's own chance of this, stated with the estimate: 85%; the middle value is on the limit's open side.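

Compound 3 and compound 4 are both reported only as limits, and no new step can be read between them. The compounds shown leave open whether any member of this series gives a number rather than a limit.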